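A few compounds are considered here, and "the series" means these few. Any claim that something is new, unique, unknown or untested is made for them only; others in the source may bear on it.

Measured so far in a functional assay on PC-3 cells (Homo sapiens) for inhibition, read by MTT assay, with a stated time of 48 h, tested at 10 uM (a higher number here means more inhibition of growth at the concentration tested, a lower number less inhibition of growth), are these compounds:

- compound 1 `Cc1cc(=O)c2c(O)c(CN3CCC(N4CCCCC4)CC3)c(O)c([C@H]3CCN(C)C[C@H]3O)c2o1` gives 17%
- compound 2 `Cc1cc(=O)c2c(O)c(CN3CCC(Cc4ccccc4)CC3)c(O)c([C@H]3CCN(C)C[C@H]3O)c2o1` gives 16%
- compound 3 `Cc1cc(=O)c2c(O)c(CN(C)CC(=O)O)c(O)c([C@H]3CCN(C)C[C@H]3O)c2o1` gives 20%

Compound 2 at 16% lies within the scatter of both compound 1 at 17% and compound 3 at 20% so the three values show no order among them.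

The next compound to test is compound 4 `Cc1cc(=O)c2c(O)c(CN3CCC(c4ccccc4)CC3)c(O)c([C@H]3CCN(C)C[C@H]3O)c2o1` which differs from compound 2 in one place: phenyl in place of benzyl on a saturated ring carbon. This is phenyl in place of benzyl on a saturated ring carbon.

Within the data shown here, one measured step bears on this change because it falls on the same ring carbon: a number 1 percentage points lower from compound 1 to compound 2 (within the scatter). Among the measured compounds shown here, no measured compound yet carries phenyl there, so the evidence is a single small step. No step beyond the scatter is therefore expected in this assay and no direction is favoured.

The expected step is a number 1 percentage points higher from compound 2 to compound 4 (within the scatter) on this reading. For compound 4 the estimate is 17% with an expected range from 8% to 27% in the coming measurement.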

Compound 4, percent growth inhibition at one concentration: 22%
Compound 4: middle estimate off by 5 percentage points, on the low side; low and high end bracket the measured number.
By their numbers in this assay, from the lowest: compounds 2, 1, 3 and 4 (each within the scatter of the next).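

At the saturated ring carbon three ring bonds from the ring nitrogen, phenyl now joins benzyl and piperidin-1-yl as a third group read in this assay: the change from benzyl gives a number 6 percentage points higher from compound 2 to compound 4 (within the scatter) and the change from piperidin-1-yl gives a number 5 percentage points higher from compound 1 to compound 4 (within the scatter) in this series. Among these compounds, with these steps, no pair among the three groups at this carbon separates beyond the scatter, whether the aromatic ring is attached directly, is attached through the benzyl carbon or is replaced by the saturated piperidin-1-yl ring. No accompanying measurement offers an explanation for these small steps. From the compounds shown here alone, it remains open whether a chlorophenyl, a carboxylic acid or a primary amine on this ring carbon would give a step beyond the scatter. A single tested concentration also leaves open how these compounds compare at higher concentrations.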